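A few compounds are considered here, and "the series" means these few. Any claim that something is new, unique, unknown or untested is made for them only; others in the source may bear on it.

Measured compounds:

- compound 1 `C[C@@H]1CCCN1c1c(C#N)c2c(N)nc(Nc3ccn(C)n3)cc2n1C`: 234 nM
- compound 2 `CN(C)c1c(C#N)c2c(N)ncnc2n1C`: 4620 nM
- compound 3 `Cn1c(NCc2ccccc2F)c(C#N)c2c(N)ncnc21`: 6060 nM

In an assay on isolated protein for inhibition of Leucine-rich repeat serine/threonine-protein kinase 2 (Homo sapiens), read by TR-FRET and LanthaScreen, with stated times of 50 min and 30 min, in the presence of a further agent that is not named here (on this read-out lower numbers stand for stronger inhibition and higher numbers for weaker inhibition), compound 2 gives 4620 nM, the second highest of the three numbers. Its nearest neighbour is compound 3, whose value of 6060 nM lies within the scatter of compound 2, so the two are treated as indistinguishable. Compound 1, with 234 nM, stands far lower, beyond the scatter, but it differs from compound 2 in more than one place, so nothing is read from that gap alone.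

Compound 4 `Cn1c(N)c(C#N)c2c(N)ncnc21` has not yet been measured. It differs from compound 2 in one place: amino in place of dimethylamino on an aromatic carbon. Among the measured compounds shown here, no pair of measured compounds differing in only one place exists in this set, so there is no directly comparable step. Compound 2 and compound 3 carry different groups at this position and give numbers within the scatter of each other, which gives no sign that the group here moves the read-out much.

For compound 4 a step of little size is expected, a 1.2-fold higher number from compound 2 to compound 4 (0.08 log units; within the scatter), with no clear direction beyond the scatter. Compound 4 is therefore estimated at 5500 nM, with a range from 2000 nM to 15000 nM.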

Compound 4, half-maximal inhibitory concentration: 14400 nM
Estimate against measurement, compound 4: 2.6-fold (0.42 log units) below, and the stated range covers the measured number.
By their numbers in this assay, from the lowest: compound 1; then compounds 2 and 3 (each within the scatter of the next); then compound 4.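

In this assay, among the compounds shown here, the change to amino gives a 3.1-fold higher number from compound 2 to compound 4 (0.49 log units; beyond the scatter), the only one-place comparison available. It shows that the group on this aromatic carbon, which sits next to the ring nitrogen and between the atoms bearing the cyano and methyl groups, can shift the read-out beyond the scatter, although the step is modest and dimethylamino goes with the lower number of this pair. The change both removes the carbons of dimethylamino and brings in a hydrogen-bond donor, and this single pair cannot separate those two differences, while no measurement at hand offers an explanation for the step.

On these data alone, it remains open whether a methylamino group, which keeps one of the two methyl groups, would fall with compound 2 or with compound 4, and whether a morpholine ring at this carbon would give a lower number than dimethylamino. Also open, as far as these compounds go, is whether the same step would appear on the core of compound 1, which differs from compound 2 in more than one place.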